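The compounds below may be only part of what the source reports. "The series", "measured", "known", "first", "only" and "open" are said of these compounds alone.

Of the compounds shown here, three of a shared core have been tested in a functional assay on 786-0 cells (Homo sapiens) for inhibition, read by sulforhodamine B assay, with a stated time of 48 h; on this read-out higher numbers stand for lower toxicity in this test and lower numbers for higher toxicity in this test. Compound 1 `Nc1cc(N)c2nc(-c3ccccc3)c(NCc3ccc(Cl)c(Cl)c3)nc2c1` carries a (3,4-dichlorobenzyl)amino group and gives 70800 nM in this assay. Compound 2 `Nc1cc(N)c2nc(-c3ccccc3)c(Oc3ccc(F)cc3)nc2c1`, which carries a 4-fluorophenoxy group instead, gives 75900 nM, the highest of the two plain numbers, though the value of compound 1 sits within the scatter of it, so the two cannot be told apart. Compound 3 `CCOC(=O)[C@H](CCC(=O)O)NC(=O)c1ccc(CNc2nc3cc(N)cc(N)c3nc2-c2ccccc2)cc1`, a much larger ester-bearing analogue, is reported only as a limit of this assay, < 100000 nM, and not as a number (the limit of < 100000 nM in this assay, at which 1 of the 3 values shown sits).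

Compound 4 `Nc1cc(N)c2nc(-c3ccccc3)c(NCc3ccc(F)cc3)nc2c1` has not yet been measured in this assay. It differs from compound 2 in one place: (4-fluorobenzyl)amino in place of 4-fluorophenoxy on an aromatic carbon. The new group resembles the benzylamino group of compound 1, differing only in the halogen pattern on the ring. Since compound 1 gives 70800 nM and compound 2 gives 75900 nM, the swap from phenoxy to benzylamino has so far shown no effect beyond the scatter.

Accordingly the step of a 1.1-fold lower number from compound 2 to compound 4 (0.02 log units; within the scatter) is expected to stay within the scatter, with no clear direction. Compound 4 is estimated at 72000 nM, most likely between 36000 nM and 140000 nM.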

Compound 4, concentration lethal to 50% of the cells: < 100000 nM
Compound 4: a limit, no number; the forecaster's own chance of this, stated with the estimate: 20%; the middle value is on the limit's open side.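

In this assay compound 4 gives < 100000 nM, which is a limit and not a number. The steps to compound 4 from compound 1 and from compound 2 therefore cannot be read. The compounds shown leave open whether (4-fluorobenzyl)amino in place of 4-fluorophenoxy changes the read-out at all, and in which direction.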